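Varying the dialkylamino group: from diisopropyl to dibutyl

A few compounds are considered here, and "the series" means these few. Any claim that something is new, unique, unknown or untested is made for them only; others in the source may bear on it.

Compound 1, `CCCCCCCCCCCCCC[C@H](O)[C@H](CN(CC)CC)NC(=O)OC(C)(C)C`, gives 18.5% in a functional assay on A549 cells (Homo sapiens) for antiproliferative activity, read by sulforhodamine B assay, with a stated time of 48 h, tested at 10 uM; a higher number here means more inhibition at the concentration tested (going by the name of the read-out), a lower number less inhibition.
Compound 2, `CCCCCCCCCCCCCC[C@H](O)[C@H](CN(C(C)C)C(C)C)NC(=O)OC(C)(C)C`, gives 22.9% in this assay.

Of the compounds shown here, two have been measured so far. Going by the values given here, on those numbers compound 2 stands highest, with compound 1 its only neighbour; the gap between them, a number 4.4 percentage points higher from compound 1 to compound 2 (within the scatter), is within the scatter, so the two cannot be told apart on this read-out.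

Compound 3, `CCCCCCCCCCCCCC[C@H](O)[C@H](CN(CCCC)CCCC)NC(=O)OC(C)(C)C`, has not yet been measured. It differs from compound 2 in one place: dibutylamino in place of diisopropylamino on a saturated chain carbon, two bonds along the chain from an amide-type nitrogen. Among the compounds with values here, the only measured step that bears on this change is the one from compound 1 to compound 2, also an exchange of one dialkylamino group for another at the same place, and that step, a number 4.4 percentage points higher from compound 1 to compound 2 (within the scatter), stayed within the scatter. The step to compound 3 is therefore expected to be of similar size, with no change beyond the scatter in either direction: a number 2.1 percentage points higher from compound 2 to compound 3 (within the scatter).

The estimate for compound 3 in this assay is accordingly 25%, expected to fall between 10% and 42%.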

Compound 3, a percentage reported as inhibition, at one concentration (the size of the read-out at that concentration, not a potency): 30%
For compound 3 the middle estimate is 5 percentage points below the measured one; the range from low to high includes it.
By their numbers in this assay, from the lowest: compounds 1, 2 and 3 (each within the scatter of the next, the first and the last beyond it).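

In this assay the exchange of diisopropylamino for dibutylamino at this place amounts to a number 7.1 percentage points higher from compound 2 to compound 3 (within the scatter) and so cannot be told apart from repeat measurement on its own. Going by these compounds alone, the exchange of diethylamino for dibutylamino, at the same saturated chain carbon, two bonds along the chain from an amide-type nitrogen, is the first change here to clear the scatter: it amounts to a number 11.5 percentage points higher from compound 1 to compound 3 (beyond the scatter) and is modest in size. Within the data shown here, compound 2 cannot be separated from compound 1 or compound 3, so the only distinction these compounds support is that between the diethylamino and dibutylamino groups, and no measurement bears on what lies behind it.

The compounds shown leave open whether a longer pair of chains, such as dihexylamino, would carry the number further, and whether a ring amine such as piperidine or morpholine would serve at this place as well as the open-chain groups. They also leave open how a free primary amine in place of the tert-butyl carbamate would read, and, with every reading taken at one concentration, they give no potency for any of the three.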